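Urea series: ring substituent on the amide nitrogen

The compounds below may be only part of what the source reports. "The series", "measured", "known", "first", "only" and "open" are said of these compounds alone.

Measured so far:
compound 1, `O=C(NCCCOc1ccc2nc(O)ccc2c1)N(C1CC1)[C@@H]1CCC[C@H]1O`, 23%
compound 2, `O=C(NCCCOc1ccc2nc(O)ccc2c1)N(C1CC1)[C@H]1CC[C@H](O)CC1`, 7%

Going by the values given here, in a functional assay on the whole organism for inhibition, with Rattus norvegicus as the target, at a dose of 30 mg/kg by the oral route (a lower number here means less inhibition, a higher number more inhibition at the dose given (going by the name of the read-out)), compound 2 stands lowest of the two numbers; its nearest neighbour is compound 1, and the only measured step, a number 16 percentage points lower from compound 1 to compound 2 (beyond the scatter), lies beyond the scatter. Compound 3, `CCCCO[C@H]1CCCC[C@@H]1N(C(=O)NCCCOc1ccc2nc(O)ccc2c1)C1CC1`, differs from compound 2 by 2-butoxycyclohexyl in place of 4-hydroxycyclohexyl on an amide-type nitrogen. Among the compounds with values here, no measured step covers this change: the one step known concerns ring size together with the position of the hydroxyl, not the exchange of a hydroxyl for a butoxy group, so it bears on compound 3 only loosely. Within the data shown here, with that single step as the only guide to how much this amide-nitrogen substituent moves the read-out, a modest upward step, a number 13 percentage points higher from compound 2 to compound 3 (beyond the scatter), is expected for compound 3, with wide uncertainty. The estimate for compound 3 in this assay is 20%, with a range from 0% to 45%.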

Compound 3, a percentage reported as inhibition, in the whole organism at one dose (the size of the read-out at that dose, not a potency): 19%
The estimate for compound 3 lay 1 percentage points above the measured number; low and high end bracket the measured number.
By their numbers in this assay, from the lowest: compound 2; then compounds 3 and 1 (each within the scatter of the next).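

In this assay, the substituent on the amide-type nitrogen accepts a larger group with no hydrogen-bond donor: 2-butoxycyclohexyl in place of 4-hydroxycyclohexyl gives a number 12 percentage points higher from compound 2 to compound 3 (beyond the scatter). Set against 2-hydroxycyclopentyl, the same group gives a number 4 percentage points lower from compound 1 to compound 3 (within the scatter), so among these compounds a free hydroxyl on the ring is not needed to reach this level of the read-out. No measurement shown here offers an explanation for either step.

Open is whether the butoxy group or its place on the ring accounts for the rise, as 2-hydroxycyclohexyl is not among the compounds shown. Also open, from the compounds shown here alone, is how a longer chain, or an amine or carboxylic acid on the chain, would read in this assay.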